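The compounds below may be only part of what the source reports. "The series", "measured", "known", "first", "only" and "open" are said of these compounds alone.

Values in a functional assay on HCT-116 cells (Homo sapiens) for inhibition, read by MTT assay, with a stated time of 72 h; a lower number here means a stronger inhibitor, a higher number a weaker inhibitor:
compound 1, `O=C1Nc2ccc([N+](=O)[O-])cc2/C1=N/NC(=S)N1CCN(c2ccccc2)CC1`: 15100 nM
compound 2, `O=C1Nc2cc(Br)ccc2/C1=N/NC(=S)N1CCN(c2ccccc2)CC1`: 14500 nM
compound 3, `Cc1ccccc1N1CCN(C(=S)N/N=C2\C(=O)Nc3ccc(Cl)cc32)CC1`: 4910 nM

Among these three, compound 3 gives the lowest number in this assay; the gaps to compound 2 and to compound 1 both lie beyond the usual scatter of repeated measurements, so compound 3 is the strongest inhibitor of the three.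

Compound 4, `O=C1Nc2ccc(Cl)cc2/C1=N/NC(=S)N1CCN(c2ccccc2[N+](=O)[O-])CC1`, has not yet been measured. It differs from compound 3 in one place: nitro in place of methyl on an aromatic carbon. Among the measured compounds shown here, no pair of measured compounds shows this same change, so nothing here tells how large such a step is. A moderate shift toward a higher number in this assay is expected, with real uncertainty in both directions. For compound 4 the estimate is 7500 nM, with a range of 2000 nM to 28000 nM, which is expected to mean a step of a 1.5-fold higher number from compound 3 to compound 4 (0.18 log units; within the scatter).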

Compound 4, half-maximal inhibitory concentration: 4570 nM
Beside the measured number, compound 4's estimate is 1.6-fold (0.22 log units) above it; low and high end bracket the measured number.
By their numbers in this assay, from the lowest: compounds 4 and 3 (each within the scatter of the next); then compounds 2 and 1 (each within the scatter of the next).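

In this assay, placing nitro instead of methyl on this aromatic carbon, ortho to a large group, gives a 1.1-fold lower number from compound 3 to compound 4 (0.03 log units; within the scatter), so the two compounds cannot be told apart. At this place, then, the assay does not separate methyl from nitro, although nitro has three heavy atoms where methyl has one and adds two hydrogen-bond acceptors. No measurement at hand bears on why this is so. From the compounds shown here alone, what an amine or a carboxylic acid would give at this same place remains open. So does whether a longer chain, such as propyl, would leave the number as little changed.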